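A few compounds are considered here, and "the series" means these few. Any claim that something is new, unique, unknown or untested is made for them only; others in the source may bear on it.

Measured compounds in a functional assay on HepG2 cells (Homo sapiens) for antiproliferative activity, read by MTT assay, with a stated time of 24 h; a lower number here means a stronger inhibitor, a higher number a weaker inhibitor:
Compound 1 `Cc1cccc(-n2cc(-c3ccccc3NS(=O)(=O)c3c[nH]c(=O)[nH]c3=O)nn2)c1` gives 3620 nM in this assay.
Compound 2 `Cc1ccccc1-n1cc(-c2cccc(NS(=O)(=O)c3c[nH]c(=O)[nH]c3=O)c2)nn1` gives 9570 nM in this assay.

Of the two numbers, compound 2 holds the higher one, and compound 1 holds the lower; the gap between them lies beyond the usual scatter, so compound 2 is the weaker inhibitor of the pair. The two differ in more than one place, so the gap cannot be tied to a single structural change.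

Compound 3 `O=c1[nH]cc(S(=O)(=O)Nc2cccc(-c3cn(-c4cccc(F)c4)nn3)c2)c(=O)[nH]1` arises from compound 2 by a single change: 3-fluorophenyl in place of 2-methylphenyl on an aromatic nitrogen. Among the compounds with values here, no measured pair shows this change, so nothing here says how large such a step is or which way it goes. The analyst therefore expects from compound 2 to compound 3 a step of a 1.2-fold lower number from compound 2 to compound 3 (0.08 log units; within the scatter), that is, nothing beyond the scatter. For compound 3 in this assay he estimates 8000 nM, within a range from 3000 nM to 20000 nM.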

Compound 3, half-maximal inhibitory concentration: > 20000 nM
Compound 3: a limit, no number; the forecaster's own chance of this, stated with the estimate: 5%; at least 2.5-fold (0.39 log units) between middle value and limit.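

In this assay compound 3 gives > 20000 nM, which is a limit of the assay and not a number. Even so, this is the first change in a single place, and it shows that the group on the aromatic nitrogen matters in this series: 3-fluorophenyl in place of 2-methylphenyl, two groups equal in heavy atoms, gives an at least 2.0-fold higher number from compound 2 to compound 3 (0.32 log units; beyond the scatter). That step marks only a floor and not a full size, and it rests on a single limit: the limit of > 20000 nM in this assay, at which 1 of the 3 values shown sits.

The pair does not separate the loss of the methyl from the arrival of the fluorine, nor does it show whether the place of the substituent on the ring counts. Also open, from the compounds shown here alone, is how plain phenyl, 2-fluorophenyl or an aminophenyl group on that nitrogen would fare in this assay.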